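The source may report more compounds than this note shows. Statements on the series, on what has been measured and on what is new or still open speak of the compounds shown alone.

Of the compounds shown here, three have been read so far in an ADME assay on microsomes from liver (Rattus norvegicus) for metabolic stability (on this read-out lower numbers stand for a shorter-lived compound and higher numbers for a longer-lived compound), and they share no single-place step. Compound 1 `CN1C(=O)COc2ccc(Nc3cc4c(cn3)ncn4CC3CC3)cc21` gives 0.417 h and compound 2 `CN1C(=O)COc2nc(Nc3cc4c(cn3)ncn4CC3CC3)ccc21` gives 0.65 h as two values within the usual scatter of each other. Compound 3 `CN1C(=O)COc2cc(Nc3ccc4ncn(CC5CC5)c4n3)cnc21` gives 0.117 h as the lowest of the three numbers, and its gaps to compound 1 and compound 2 both lie beyond the scatter.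

Compound 4 `CN1C(=O)COc2cc(Nc3cc(C(F)(F)F)c4ncn(CC5CC5)c4n3)cnc21` departs from compound 3 in one place. The change is trifluoromethyl in place of hydrogen on an aromatic carbon and it falls on an aromatic carbon of the six-membered aromatic ring with 1 nitrogen, opposite the ring nitrogen. For the measured compounds named here, no measured compound carries a trifluoromethyl, so the series gives no direct guide to this change. Going by the values given here, the only anchor is compound 3 at 0.117 h as the low end of the series, which leaves more room upward than downward. A small upward move is therefore expected, with no step beyond the scatter as the central case. The estimated change is a 1.7-fold higher number from compound 3 to compound 4 (0.23 log units; within the scatter) in this assay as a tentative expectation. Compound 4 is estimated at 0.2 h with an expected range from 0.08 h to 0.5 h on repeat measurements.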

Compound 4, half-life: 1.12 h
The estimate for compound 4 lay 5.6-fold (0.75 log units) below the measured number; measured number above the stated range.
By their numbers in this assay, from the lowest: compound 3; then compounds 1, 2 and 4 (each within the scatter of the next, the first and the last beyond it).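

In this assay, for the compounds shown here, trifluoromethyl in place of hydrogen on an aromatic carbon, opposite the ring nitrogen, gives a 9.6-fold higher number from compound 3 to compound 4 (0.98 log units; beyond the scatter) and so provides the first single-place step. Going by these compounds alone, this shows that the read-out responds strongly to a single substitution at this carbon of the six-membered aromatic ring with 1 nitrogen, which the earlier compounds, sharing no such step, could not show. No measurement shown here bears on the reason for this rise.

This single step cannot say whether the rise belongs to trifluoromethyl itself or would also come with a smaller or different group on the same carbon, such as a methyl, a chlorine atom, a nitrile or a methoxy group. It also leaves open whether trifluoromethyl would give a step of similar size on the cores of compound 1 and compound 2, or at another aromatic carbon of the ring that carries it in compound 4.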